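Oxime series: ethoxycarbonyl to methyl on the oxime carbon

The source may report more compounds than this note shows. Statements on the series, on what has been measured and on what is new or still open speak of the compounds shown alone.

The series is followed in a functional assay (blood) for inhibition, with Homo sapiens as the target; on this read-out lower numbers stand for stronger inhibition and higher numbers for weaker inhibition. Of the compounds shown here, three have numbers so far. Compound 1 `CCOC(=O)/C(=N\O)c1ccc(Sc2cc(F)cc(C3CCOCC3)c2)cc1` gives 170 nM in this assay. Compound 2 `CO[C@]1(c2cc(F)cc(Sc3ccc(/C(C)=N/OCC#N)cc3)c2)CCO[C@@H](C)C1` gives 40 nM, and compound 3 `COC1(c2cc(F)cc(Sc3ccc4c(c3)CC/C4=N\O)c2)CCOCC1` gives 290 nM. Of the three numbers, compound 1 holds the second highest; its number and that of compound 3 lie within the usual scatter of each other, so nothing is read into their difference, whereas compound 2 sits clearly lower and is the stronger inhibitor of the three by a margin beyond the scatter.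

The next step leaves compound 1 for compound 4 `C/C(=N\O)c1ccc(Sc2cc(F)cc(C3CCOCC3)c2)cc1`, which has not yet been measured in this assay. The change is methyl in place of ethoxycarbonyl on a carbon with a double bond to nitrogen. Going by the values given here, no measured pair in the set isolates this change, so its size is not known from the data. Compound 2, which also carries a methyl on the carbon with a double bond to nitrogen, gives 40 nM, but it differs from compound 4 at several other places, so it serves only as a loose pointer. The expectation is a step no larger than the scatter, if anything toward a lower number. Compound 4 is therefore estimated at 120 nM, with a range from 40 nM to 350 nM; this estimate corresponds to an expected step of a 1.4-fold lower number from compound 1 to compound 4 (0.15 log units; within the scatter).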

Compound 4, half-maximal inhibitory concentration: 80 nM
Compound 4: middle estimate off by 1.5-fold (0.18 log units), on the high side, and the stated range covers the measured number.
By their numbers in this assay, from the lowest: compounds 2 and 4 (each within the scatter of the next); then compounds 1 and 3 (each within the scatter of the next).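

In this assay, going by these compounds alone, this is the first pair that isolates a single change, and it covers a carbon with a double bond to nitrogen whose other neighbours are an aromatic carbon and the double-bonded nitrogen: methyl in place of ethoxycarbonyl gives a 2.1-fold lower number from compound 1 to compound 4 (0.33 log units; beyond the scatter), a modest step but one that clears the scatter. At this position, then, the read-out does not depend on keeping the ethoxycarbonyl with its 5 heavy atoms and 2 hydrogen-bond acceptors, since the methyl, with 1 heavy atom and no hydrogen-bond acceptors, gives the lower number on an otherwise unchanged structure. No supporting measurement bears on what lies behind this step.

With only these two groups at this position, the compounds shown leave open how an ethyl, a carboxylic acid or a primary amide on the same carbon would read, and so whether the number follows the size of the group or something else. Compound 2 differs from compound 4 in several places, so the compounds shown do not tell whether this step would carry over to the rest of the series.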